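A few compounds are considered here, and "the series" means these few. Any claim that something is new, unique, unknown or untested is made for them only; others in the source may bear on it.

- Compound 1 `CCCCNc1nc(N)nc2ccn(CC(=O)NC)c12`: > 24000 nM, a limit
- Compound 2 `CCCCNc1nc(N)nc2ccn(CC=C(C)C)c12`: > 24000 nM, a limit
- Compound 3 `CCCCNc1nc(N)nc2ccn(Cc3nccs3)c12`: > 24000 nM, a limit

In an ADME assay on HEK293 cells (Homo sapiens) for cytotoxicity, read by ATP content, with a stated time of 6 h (on this read-out higher numbers stand for lower toxicity in this test and lower numbers for higher toxicity in this test), compound 3 gives > 24000 nM, which is a limit of the assay and not a number. The same holds across this small set, which shows (the limit of > 24000 nM in this assay, at which 3 of the 3 values shown sit).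

Compound 4 `CCCCNc1nc(N)nc2ccn(Cc3ccccn3)c12` keeps the shared core and changes one group: pyridin-2-yl in place of 1,3-thiazol-2-yl on a saturated chain carbon bound to an aromatic nitrogen. In words, pyridin-2-yl stands in place of 1,3-thiazol-2-yl on a saturated chain carbon bound to an aromatic nitrogen.

The measured steps that bear on this change are those at the same place: a step that the two limits leave unreadable from compound 1 to compound 2, a step that the two limits leave unreadable from compound 1 to compound 3 and a step that the two limits leave unreadable from compound 2 to compound 3. None of them has a readable size, so they offer no measured size to carry over. All three groups tried there gave the same limit, so no step beyond the usual scatter is expected in this assay, and another limit is the likeliest reading. The expected step is a number no higher from compound 3 to compound 4 (the limit leaves the size open). The estimate for compound 4 is 24000 nM, with an expected range of 12000 nM to 50000 nM.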

Compound 4, half-maximal cytotoxic concentration: > 24000 nM
Compound 4 ended at the assay's limit; the forecaster's own chance of this, stated with the estimate: 85%; the middle value lies on the limit itself.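

In this assay compound 4 gives > 24000 nM, which is a limit of the assay and not a number. No step between compounds 1, 2, 3 and 4 can be read, because all four sit at the same limit: the limit of > 24000 nM in this assay, at which 4 of the 4 values shown sit.

The compounds shown leave open whether swapping these groups changes the read-out at all, and by how much.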